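Adding a pentyl chain to compound 3

The compounds below may be only part of what the source reports. "The series", "measured", "known", "first", "only" and "open" are said of these compounds alone.

Measured in an ADME assay on HEL cells (Homo sapiens) for cytotoxicity, with a stated time of 3 days; a higher number here means that more compound is tolerated, a lower number that less compound is tolerated:
compound 1 `CCCc1ccc(C#Cc2cc3cn([C@H]4C[C@H](O)[C@@H](CO)O4)c(=O)nc3o2)cc1`: > 120000 nM (a limit)
compound 2 `Cc1ccc(C#Cc2cc3cn([C@H]4C[C@H](O)[C@@H](CO)O4)c(=O)nc3o2)cc1`: 510000 nM
compound 3 `O=c1nc2oc(C#Cc3ccccc3)cc2cn1[C@H]1C[C@H](O)[C@@H](CO)O1`: > 570000 nM (a limit)

Compound 3 has no number in this assay, only the limit > 570000 nM. Compound 1 also has only a limit, so compound 2 alone gives a true number. Compound 4 `CCCCCc1ccc(C#Cc2cc3cn([C@H]4C[C@H](O)[C@@H](CO)O4)c(=O)nc3o2)cc1` differs from compound 3 by pentyl in place of hydrogen on an aromatic carbon, para to a large group.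

Among the compounds with values here, three measured steps bear on this change, all of them running towards a shorter chain or none. Removing propyl gives a step that the two limits leave unreadable from compound 1 to compound 3. Removing methyl gives an at least 1.1-fold higher number from compound 2 to compound 3 (0.04 log units; that floor lies within the scatter). Shortening propyl to methyl gives a step that the limit leaves unreadable from compound 1 to compound 2. None of them shows a change beyond the scatter, so the size of a chain effect remains unmeasured.

The nearest chain is the propyl of compound 1, whose limit is > 120000 nM. Compound 4 is therefore read against that figure, and a moderate fall is expected, with a wide margin and a good chance of another limit. The expected change is an at least 7.1-fold lower number from compound 3 to compound 4 (0.85 log units; beyond the scatter). Compound 4 is expected at 80000 nM, with an estimated range from 20000 nM to 300000 nM.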

Compound 4, half-maximal cytotoxic concentration: 110000 nM
For compound 4 the middle estimate is 1.4-fold (0.14 log units) below the measured one, within the range that was stated.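

In this assay, within the data shown here, compound 4 gives the first steps at this position that clear the scatter: pentyl in place of hydrogen brings an at least 5.1-fold lower number from compound 3 to compound 4 (0.71 log units; beyond the scatter), and lengthening methyl to pentyl brings a 4.6-fold lower number from compound 2 to compound 4 (0.67 log units; beyond the scatter), so a long chain on this aromatic carbon does lower the tolerated concentration. Against propyl the result is an at least 1.0-fold lower number from compound 1 to compound 4 (0.03 log units; that floor lies within the scatter), so no difference between these two chains can be read. Compound 1 has only a limit, not a number: the limit of > 120000 nM in this assay, at which 1 of the 4 values shown sits.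

The compounds shown leave open how the number changes between methyl and pentyl, and whether it keeps falling with a longer chain such as octyl. They also leave open whether a pentyl chain ending in a hydroxyl group or an amine would give the same fall as the all-carbon chain of compound 4.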